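The source may hold more compounds than are shown below. What is called first, only, known or untested is meant among the compounds shown, and "the series" means these compounds.

Of the compounds shown here, three sharing one core have been tested in an ADME assay on BJ cells (Homo sapiens) for cytotoxicity, with a stated time of 72 h; a higher number here means that more compound is needed for the effect, a lower number that less compound is needed. Compound 1 `Cc1cc(NC(=O)Nc2ccccc2F)c2ccccc2n1` gives > 25000 nM, which is a limit of the measurement rather than a number. Compound 2 `Cc1cc(NC(=O)Nc2cccc(C(F)(F)F)c2)c2ccccc2n1` likewise gives > 25000 nM, again a limit. Compound 3 `Cc1cc(NC(=O)Nc2cccnc2)c2ccccc2n1` gives > 25000 nM, also a limit. Among the compounds with values here, compound 3 therefore stands where every compound so far stands: at the limit of > 25000 nM in this assay, at which 3 of the 3 values shown sit, with no number to rank it.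

Within the data shown here, the only single-point change among the measured compounds, a step that the two limits leave unreadable from compound 1 to compound 3, cannot be read because both ends are limits.

Compound 4 `Cc1cc(NC(=O)Nc2cccc(F)c2)c2ccccc2n1` is not yet measured. It differs from compound 3 by 3-fluorophenyl in place of pyridin-3-yl on an amide-type nitrogen. Among the measured compounds shown here, no measured step bears on this change with a readable size, so the expectation for compound 4 rests on where all three measured compounds sit. The step from compound 3 to compound 4 is expected to be a step that the limit leaves unreadable from compound 3 to compound 4, most likely again a limit. Compound 4 is estimated at 40000 nM, within a range from 20000 nM to 100000 nM.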

Compound 4, half-maximal effective concentration: > 25000 nM
Compound 4: a limit, no number; the forecaster's own chance of this, stated with the estimate: 85%; the middle value is on the limit's open side.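

Compound 4 also gives only a limit, so its steps from compound 1, compound 2 and compound 3 cannot be read, with no number at either end of any step: the limit of > 25000 nM in this assay, at which 4 of the 4 values shown sit.

The compounds shown leave open how much of any of them is needed for an effect in this assay, and so how these changes compare in size.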